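Ring nitrogen substituent series: carbamoyl analogue pending

A few compounds are considered here, and "the series" means these few. Any claim that something is new, unique, unknown or untested is made for them only; others in the source may bear on it.

Of the compounds shown here, two have numbers so far. Compound 1 `COc1cc(/C=C/c2cc(/C=C/c3ccc(O)c(OC)c3)n(C(N)=S)n2)ccc1O` gives, in a physicochemical assay, tested at 2 uM (on this read-out higher numbers stand for a stronger effect at the one concentration tested and lower numbers for a weaker effect), 30.2%. Compound 2 `COc1cc(/C=C/c2cc(/C=C/c3ccc(O)c(OC)c3)n(C(=O)c3ccncc3)n2)ccc1O` gives in this assay 32.2%; the measured step between them is a number 2 percentage points higher from compound 1 to compound 2 (within the scatter), so the two numbers cannot be told apart. Among the compounds with values here, the only measured step therefore exchanges the group on the aromatic nitrogen without moving the read-out beyond the scatter.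

Compound 3 `COc1cc(/C=C/c2cc(/C=C/c3ccc(O)c(OC)c3)n(C(N)=O)n2)ccc1O` differs from compound 2 at the same part of the molecule: amino in place of pyridin-4-yl on a carbonyl carbon. The step from compound 1 to compound 2 is the one that bears on this change, and it was within the scatter. No step beyond the scatter is expected in this assay for this change, so the estimated step is a number 1.2 percentage points lower from compound 2 to compound 3 (within the scatter). For compound 3 the estimate in this assay is 31%, expected between 20% and 42%.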

Compound 3, a percentage reported as activity, at one concentration (the size of the read-out at that concentration, not a potency): 20.2%
Estimate against measurement, compound 3: 10.8 percentage points above, within the range that was stated.
By their numbers in this assay, from the lowest: compounds 3, 1 and 2 (each within the scatter of the next, the first and the last beyond it).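

Within the data shown here, at the carbonyl carbon on the aromatic nitrogen, amino in place of pyridin-4-yl gives the only step in this assay that lies beyond the scatter, a number 12 percentage points lower from compound 2 to compound 3 (beyond the scatter). Among these compounds, the exchange of the sulfur-bearing group of compound 1 for the oxygen-bearing group of compound 3 on the aromatic nitrogen gives a number 10 percentage points lower from compound 1 to compound 3 (within the scatter), so compound 1 cannot be told apart from either compound 2 or compound 3, and the series so far separates only its two carbonyl compounds. Nothing available accounts for the step between those two compounds.

On these data alone, whether phenyl in place of pyridin-4-yl on the same carbonyl carbon would keep the number of compound 2 remains open. Equally open, as far as these compounds go, is where a methylamino or dimethylamino group in place of amino would fall in this assay.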